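This account rests on a few compounds, and the source may have more. Where it says the series, first, only, none or still open, it means among the compounds named here.

Measured so far:
- compound 1, `Cc1ccc2[nH]c(SCC(=O)N3CCC[C@H]3C(=O)Nc3ccccc3-n3cccc3)nc2c1`: 0.2 nM
- compound 2, `O=C(Nc1ccccc1-c1ccccc1)[C@@H]1CCCN1C(=O)CSc1nc2ccccc2[nH]1`: 0.6 nM
- compound 3, `O=C(Nc1ccc(-c2ccccc2)cc1)[C@@H]1CCCN1C(=O)CSc1nc2ccccc2[nH]1`: 11 nM

All three share a core built from a proline amide linked through a thioether to a benzimidazole; they differ in what hangs on the anilide ring. In an assay on CHO cells for displacement of a labelled ligand from Orexin receptor type 2 (Homo sapiens) (on this read-out higher numbers stand for weaker inhibition and lower numbers for stronger inhibition), compound 1 gives 0.2 nM and compound 2 gives 0.6 nM. Compound 3 gives 11 nM, the highest of the three numbers, which means the weakest inhibition in this set; its nearest neighbour is compound 2, and the gap between them is beyond the usual scatter.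

Compound 4, `O=C(Nc1ccccc1)[C@@H]1CCCN1C(=O)CSc1nc2ccccc2[nH]1`, has not yet been measured. It differs from compound 3 in one spot: hydrogen in place of phenyl on an aromatic carbon, the ring position being on an aromatic carbon of a six-membered aromatic ring of carbon only, para to a large group. Within the data shown here, no pair among the measured compounds shows this exact change, so there is no direct step to lean on. The anilide of compound 4 carries no substituent at all, whereas every measured compound carries some aromatic group on that ring. The expectation is a modest step from compound 3 to compound 4 toward weaker inhibition, of size a 2.7-fold higher number from compound 3 to compound 4 (0.44 log units; beyond the scatter), possibly within the scatter. Compound 4 is therefore estimated at 30 nM, with a likely range from 6 nM to 200 nM.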

Compound 4, inhibition constant: 560 nM
Beside the measured number, compound 4's estimate is 19-fold (1.27 log units) below it; the measured number lies above the stated range.
By their numbers in this assay, from the lowest: compound 1; then compound 2; then compound 3; then compound 4.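

Compound 4 shows how much the anilide ring's phenyl counts on this shared core. In this assay, putting hydrogen in place of phenyl on the aromatic carbon para to a large group gives a 51-fold higher number from compound 3 to compound 4 (1.71 log units; beyond the scatter) and is a large change, beyond the scatter. The same swap, read against the other phenyl-bearing compound, gives a 930-fold higher number from compound 2 to compound 4 (2.97 log units; beyond the scatter), also large and beyond the scatter, so in both comparisons the bare ring goes with much weaker inhibition. Nothing measured here explains why the loss of this phenyl has so great an effect.

As far as these compounds go, what remains open is how much of the phenyl is needed, since nothing between a full phenyl ring and a lone hydrogen appears at this position: a methyl group or a chlorine atom there could recover little, part or all of the lost inhibition. From the compounds shown here alone, it is also open whether an aromatic ring is needed at all, or whether a saturated cyclohexyl ring or a basic amine in the same place would serve equally well.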